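Nitro in Place of Methoxy on a Benzoxazine Side Ring

The source may hold more compounds than are shown below. What is called first, only, known or untested is meant among the compounds shown, and "the series" means these compounds.

Of the compounds shown here, two sharing one core have been measured in a functional assay on MCF7 cells (Homo sapiens) for inhibition, read by MTT assay, with a stated time of 48 h, tested at 15 ug/mL; on this read-out lower numbers stand for less inhibition of growth and higher numbers for more inhibition of growth at the one concentration tested. Compound 1 `COc1cccc2c1OCN(c1ccc3oc(-c4ccccc4)cc(=O)c3c1)C2` gives 54% in this assay, the higher of the two numbers. Compound 2 `O=c1cc(-c2ccccc2)oc2ccc(N3COc4c(Br)cc(Br)cc4C3)cc12` gives 13.6% in this assay, a number that lies far enough below that of compound 1 to stand beyond the scatter. Compound 2 differs from compound 1 in more than one place, so its number shows only where it stands, not what any single change does.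

Compound 3 `O=c1cc(-c2ccccc2)oc2ccc(N3COc4c(cccc4[N+](=O)[O-])C3)cc12` is the next compound awaiting measurement. It differs from compound 1 in one place: nitro in place of methoxy on an aromatic carbon. On these data alone, no comparison of two measured compounds isolates this change, so its effect is unknown. For the measured compounds named here, the only guidance is that compound 1 gives 54% and compound 2, with a different pair of substituents on the same ring, gives 13.6%. On that basis compound 3 is expected to remain somewhat below compound 1, with a step from compound 1 to compound 3 estimated at a number 14 percentage points lower from compound 1 to compound 3 (beyond the scatter). For compound 3 the estimated growth inhibition is 40%, with a range from 15% to 65%.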

Compound 3, percent growth inhibition at one concentration: 55.9%
Compound 3: the middle estimate sits 15.9 percentage points below what was measured; the measured number falls inside the stated range.
By their numbers in this assay, from the lowest: compound 2; then compounds 1 and 3 (each within the scatter of the next).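

In this assay, for the compounds shown here, nitro in place of methoxy on this aromatic carbon gives a number 1.9 percentage points higher from compound 1 to compound 3 (within the scatter), the first comparison of two measured compounds that isolates a single change at this position. The step lies within the scatter, so this read-out does not tell the two groups apart here, even though the swap replaces a group of 2 heavy atoms and 1 hydrogen-bond acceptor with one of 3 heavy atoms and 2 hydrogen-bond acceptors. No measurement in hand bears on why the two compounds read alike.

The compounds shown leave open whether this carbon would accept other groups equally well, such as an amine, a carboxylic acid or a longer chain like butoxy, and what plain hydrogen at this carbon would give. Going by these compounds alone, they also leave open whether compound 1 and compound 3 would still read alike across a range of concentrations, as each has a reading at only the one concentration tested.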